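Fluorine Placement on the Piperazine Aryl Group and A3 Binding

The source may report more compounds than this note shows. Statements on the series, on what has been measured and on what is new or still open speak of the compounds shown alone.

The series shares one core, shown for compound 1 as `Nc1scc(CN2CCN(c3cccc(F)c3)CC2)c1C(=O)c1ccc(Cl)cc1`, and varies only the fluorinated phenyl ring on an amine nitrogen in a ring. In an assay on CHO cells for displacement of a labelled ligand from adenosine receptor A3 (Homo sapiens), read by scintillation counting, with a stated time of 120 min, tested at 10 uM (a higher number here means more inhibition at the concentration tested (going by the name of the read-out), a lower number less inhibition), compound 1 gives 4%. Compound 2, `Nc1scc(CN2CCN(c3ccc(F)cc3F)CC2)c1C(=O)c1ccc(Cl)cc1`, gives 0% in this assay, the lowest of the two numbers, and the change was a number 4 percentage points lower from compound 1 to compound 2 (within the scatter). Compound 3, `Nc1scc(CN2CCN(c3cc(F)ccc3F)CC2)c1C(=O)c1ccc(Cl)cc1`, carries 2,5-difluorophenyl in place of 2,4-difluorophenyl on an amine nitrogen in a ring. For the measured compounds named here, only one measured step bears on this kind of change, the move from compound 1 to compound 2, and it stayed within the scatter, so no step beyond the scatter is expected in this assay for compound 3 either. On that basis compound 3 is expected to give an estimated 2%, with a range from -8% to 13%, which means an expected step of a number 2 percentage points higher from compound 2 to compound 3 (within the scatter).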

Compound 3, a percentage reported as inhibition, at one concentration (the size of the read-out at that concentration, not a potency): 2%
Estimate against measurement, compound 3: no gap at the digits printed, and the stated range covers the measured number.
By their numbers in this assay, from the lowest: compounds 2, 3 and 1 (each within the scatter of the next).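

In this assay, for the compounds shown here, rearranging the same atoms, with 2,5-difluorophenyl in place of 2,4-difluorophenyl on the amine nitrogen in the ring, gives a number 2 percentage points higher from compound 2 to compound 3 (within the scatter), so this change of fluorine pattern on the aryl group shows no step that can be told from the scatter. Fluoro in place of hydrogen on an aromatic carbon gives a number 2 percentage points lower from compound 1 to compound 3 (within the scatter), which means that the difluorophenyl groups in both arrangements now stand within the scatter of the 3-fluorophenyl group of compound 1.

On these data alone, whether a chlorine, a methoxy group or an amine on this aryl ring would give a step beyond the scatter in this assay stays open. Nothing on hand offers an explanation for these numbers.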